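Replacing 3,4-dimethoxyphenyl with thiophen-2-yl in compound 2

The source may hold more compounds than are shown below. What is called first, only, known or untested is meant among the compounds shown, and "the series" means these compounds.

In a functional assay on THP-1 cells (Homo sapiens) for inhibition, read by sulforhodamine B assay, with a stated time of 48 h, tested at 50 uM (a lower number here means less inhibition of growth, a higher number more inhibition of growth at the concentration tested), compound 1 (`COc1cc(/C=C/C(=O)/C=C/c2cccc3ccccc23)ccc1OCc1cn(CCOc2cc(=O)oc3ccccc23)nn1`) reaches 89% in the test, compound 3 (`COc1cc(/C=C/C(=O)/C=C/c2cccc3ccccc23)ccc1OCc1cn(CCCCOc2cc(=O)oc3ccccc23)nn1`) reaches 54% in the test, and compound 2 (`COc1ccc(/C=C/C(=O)/C=C/c2ccc(OCc3cn(CCCCCOc4cc(=O)oc5ccccc45)nn3)c(OC)c2)cc1OC`) reaches 47% in the test. Compound 2 thus sits within the scatter of compound 3 and beyond the scatter under compound 1. Compound 4 (`COc1cc(/C=C/C(=O)/C=C/c2cccs2)ccc1OCc1cn(CCCCCOc2cc(=O)oc3ccccc23)nn1`) changes one group of compound 2 as follows: thiophen-2-yl in place of 3,4-dimethoxyphenyl on a double-bonded chain carbon bound to a double-bonded chain carbon on a double-bonded chain carbon bound to a double-bonded chain carbon. Going by the values given here, no measured pair isolates this swap, and compound 1 and compound 3 each differ from compound 2 in more than one place. So no step beyond the scatter is expected in this assay for this swap. The expected change is a number 3 percentage points higher from compound 2 to compound 4 (within the scatter) in size, small and uncertain. The estimate for compound 4 is 50% with an expected range from 32% to 70% across repeat measurements.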

Compound 4, percent growth inhibition at one concentration: 34%
Compound 4: middle estimate off by 16 percentage points, on the high side; the range from low to high includes it.
By their numbers in this assay, from the lowest: compound 4; then compounds 2 and 3 (each within the scatter of the next); then compound 1.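

In this assay, going by these compounds alone, this position proves sensitive to the change: thiophen-2-yl in place of 3,4-dimethoxyphenyl gives a number 13 percentage points lower from compound 2 to compound 4 (beyond the scatter) and is the first single-place comparison. In this one pair, the five-membered aromatic ring with fewer heavy atoms goes with less growth inhibition. No measurement here explains the drop.
As far as these compounds go, it remains open whether the ring swap or the loss of the two methoxy groups matters more. Plain phenyl or 4-methoxyphenyl in this place would help separate the two.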